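This account rests on a few compounds, and the source may have more. Where it says the series, first, only, none or still open, it means among the compounds named here.

Measured compounds:
- Compound 1 `CNC(=O)c1cccn(Cc2ccccc2)c1=O` — a physicochemical assay for lipophilicity, at pH 7.4; a higher number here means a more lipophilic compound, a lower number a more polar compound: compound 1 gives 3
- Compound 2 `CNC(=O)c1cc(C(=O)NC2CC2)cn(Cc2cccc3[nH]ccc23)c1=O` — in this assay compound 2 gives 2.9

Compound 2 has the lower of the two numbers, but its nearest neighbour is compound 1, whose value sits only a little higher, within the scatter of this assay, so the two cannot be told apart on these data.

Compound 3 `CNC(=O)c1cc(C(=O)NC2CC2)cn(Cc2cccc3cc[nH]c23)c1=O` is not yet measured. It differs from compound 2 in one place: 1H-indol-7-yl in place of 1H-indol-4-yl on a saturated chain carbon bound to an aromatic nitrogen. The two have the same atoms, joined differently, and the group that leaves and the group that enters each carry one hydrogen-bond donor and no hydrogen-bond acceptor. Within the data shown here, with no step between measured compounds to lean on, the expected step of no change at the digits printed from compound 2 to compound 3 (within the scatter) is none beyond the scatter. Compound 3 is therefore expected to give 2.9, in a range from 2.5 to 3.3.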

Compound 3, distribution coefficient: 3.7
The estimate for compound 3 lay 0.80 log units below the measured number, and the stated range ends below it.
By their numbers in this assay, from the lowest: compounds 2 and 1 (each within the scatter of the next); then compound 3.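

Putting 1H-indol-7-yl in place of 1H-indol-4-yl on a saturated chain carbon bound to an aromatic nitrogen gives, in this assay, a number 0.80 log units higher from compound 2 to compound 3 (beyond the scatter). Among these compounds, this is the first step read at this position, and it shows that the way the indole is joined can move this number even when the atoms and the counted hydrogen-bond donors and acceptors stay the same. The data shown offer no separate measurement that could explain the step.

Still open, going by these compounds, is where 1H-indol-5-yl or 1H-indol-6-yl would fall in this assay, and so whether 1H-indol-7-yl stands alone among the joining points. Also open, on these data alone, is how a quite different group at this place, such as an amine or a carboxylic acid, would read.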